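The source may hold more compounds than are shown below. What is called first, only, known or untested is meant among the compounds shown, and "the series" means these compounds.

Values in a functional assay on QG-56 cells (Homo sapiens) for antiproliferative activity; on this read-out higher numbers stand for weaker inhibition and lower numbers for stronger inhibition:
- Compound 1 `COc1ccc(C(O)(c2cc3cc([N+](=O)[O-])cc(-c4ccccc4)c3o2)c2cncn2C)cc1`: 4970 nM
- Compound 2 `Cn1cncc1C(O)(c1ccc(I)cc1)c1cc2cc([N+](=O)[O-])cc(-c3ccccc3)c2o1`: > 10000 nM
- Compound 3 `Cn1cncc1C(O)(c1ccc(C(=O)O)cc1)c1cc2cc([N+](=O)[O-])cc(-c3ccccc3)c2o1`: > 10000 nM

Compound 3 has only a limit, > 10000 nM, and no number. The same ceiling applies to compound 2, as shown here: the limit of > 10000 nM in this assay, at which 2 of the 3 values shown sit.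

Compound 4 `Cn1cncc1C(O)(c1ccc(C#N)cc1)c1cc2cc([N+](=O)[O-])cc(-c3ccccc3)c2o1` has cyano in place of carboxy on an aromatic carbon, para to a large group: cyano in place of carboxy on an aromatic carbon.

Among the measured compounds shown here, no measured step covers this exchange directly, but three steps at the same place bear on it. The first is an at least 2.0-fold higher number from compound 1 to compound 2 (0.30 log units; that floor lies within the scatter). The second is an at least 2.0-fold higher number from compound 1 to compound 3 (0.30 log units; that floor lies within the scatter). Both are floors rather than sizes. The third, a step that the two limits leave unreadable from compound 2 to compound 3, gives no size at all.

For the measured compounds named here, the only number is that of compound 1, 4970 nM, so the expectation leans on it. A real value for compound 4 is expected in the same region, although another limit in this assay remains quite possible. The expected change is towards a lower number, meaning stronger inhibition, and its size is poorly defined. The estimated step is an at least 2.0-fold lower number from compound 3 to compound 4 (0.30 log units; that floor lies within the scatter). Compound 4 is estimated at 5000 nM, with an expected range of 1000 nM to 10000 nM.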

Compound 4, half-maximal inhibitory concentration: 1480 nM
Compound 4: the middle estimate sits 3.4-fold (0.53 log units) above what was measured; the measured number falls inside the stated range.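

In this assay, the change to 4-cyanophenyl gives the first readable gain at this position, an aromatic carbon para to a large group: the step is a 3.4-fold lower number from compound 1 to compound 4 (0.53 log units; beyond the scatter), so a group here can improve on methoxy and not only lose activity. Against the other two groups, the steps are an at least 6.7-fold lower number from compound 3 to compound 4 (0.82 log units; beyond the scatter) and an at least 6.7-fold lower number from compound 2 to compound 4 (0.82 log units; beyond the scatter), and both are floors rather than sizes because the compared compounds carry only a limit: the limit of > 10000 nM in this assay, at which 2 of the 4 values shown sit. Among the compounds shown here, the position is therefore clearly sensitive to what it carries, with cyano now ahead of methoxy, carboxy and iodo, whereas the earlier compounds gave one number and no step of readable size.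

As far as these compounds go, the true distance of compound 2 and compound 3 from compound 4 stays open, as does any step between those two limits, and the data do not say what sets cyano apart from the other groups. Also open, from the compounds shown here alone, is whether an amide, an aminomethyl group or a longer chain ending in a nitrile on this same aromatic carbon would hold, extend or lose the gain seen with cyano.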